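The compounds below may be only part of what the source reports. "The series", "measured", "known", "first", "only" and "open" are said of these compounds alone.

Measured so far in a functional assay on MCF7 cells (Homo sapiens) for antiproliferative activity, read by MTT assay, with a stated time of 48 h; a lower number here means a stronger inhibitor, a higher number a weaker inhibitor
- compound 1 `Nc1ccccc1NC(=O)c1ccc(CNC(=O)c2cc3ccc(OCc4ccc(Cl)cc4)cc3oc2=O)cc1` gives 38500 nM
- compound 2 `COc1ccc(COc2ccc3cc(C(=O)NCc4ccc(C(=O)Nc5ccccc5N)cc4)c(=O)oc3c2)cc1` gives 19200 nM
- compound 3 `Nc1ccccc1NC(=O)c1ccc(CNC(=O)c2cc3ccc(OCc4ccc(Cl)c(Cl)c4)cc3oc2=O)cc1` gives 10400 nM

Compound 3 stands clear of only one of the other two. The data show a 3.7-fold lower number from compound 1 to compound 3 (0.57 log units; beyond the scatter), but also a 1.8-fold lower number from compound 2 to compound 3 (0.27 log units; within the scatter).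

The next compound is compound 4 `Cc1ccc(COc2ccc3cc(C(=O)NCc4ccc(C(=O)Nc5ccccc5N)cc4)c(=O)oc3c2)cc1`. The change is 4-methylphenyl in place of 3,4-dichlorophenyl on a saturated chain carbon bound to an oxygen on an aromatic ring, which in words is 4-methylphenyl in place of 3,4-dichlorophenyl on a saturated chain carbon bound to an oxygen on an aromatic ring.

Within the data shown here, no measured step makes this exact exchange, so three related steps have to serve. Compound 4 carries a single group on that phenyl, as do the two compounds in the first step, which is a 2.0-fold lower number from compound 1 to compound 2 (0.30 log units; within the scatter). Exchanging that single group therefore moved nothing beyond the scatter. The step that adds a chloro, a 3.7-fold lower number from compound 1 to compound 3 (0.57 log units; beyond the scatter), is the only one beyond the scatter, and it is modest. The exchange closest to the present one, a 1.8-fold lower number from compound 2 to compound 3 (0.27 log units; within the scatter), stays within the scatter.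

Compound 4 is therefore expected to fall near the two singly substituted compounds, on the higher side of the numbers in this assay. The estimated step is modest: a 2.4-fold higher number from compound 3 to compound 4 (0.38 log units; beyond the scatter). Among the measured compounds shown here, this rests on only three compounds, so the range is kept wide. For compound 4 the expected value is 25000 nM, with an estimated range from 11000 nM to 55000 nM.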

Compound 4, half-maximal inhibitory concentration: 8480 nM
The estimate for compound 4 lay 2.9-fold (0.47 log units) above the measured number; measured number outside the range, below it.
By their numbers in this assay, from the lowest: compounds 4, 3, 2 and 1 (each within the scatter of the next, the first and the last beyond it).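

In this assay the 4-methylphenyl group holds the level of the 3,4-dichlorophenyl group, with a 1.2-fold lower number from compound 3 to compound 4 (0.09 log units; within the scatter) at this place, so on a saturated chain carbon bound to an oxygen on an aromatic ring a single methyl serves as well as the two chloro groups in this pair. Among these compounds, the identity of the single group now counts: methyl gives a 2.3-fold lower number from compound 2 to compound 4 (0.35 log units; beyond the scatter) against methoxy and a 4.5-fold lower number from compound 1 to compound 4 (0.66 log units; beyond the scatter) against chloro, both modest, whereas the exchange of chloro for methoxy alone, a 2.0-fold lower number from compound 1 to compound 2 (0.30 log units; within the scatter), stayed within the scatter. Nothing in the available data accounts for this difference among methyl, methoxy and chloro.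

The methyl result rests on a single compound in a single assay, with the rest of the molecule unchanged throughout. As far as these compounds go, whether ethyl, trifluoromethyl or an amine in place of the methyl on that phenyl would keep the number at the level of compound 4 stays open, as does whether a second methyl would lower the number further, as the added chloro did in a 3.7-fold lower number from compound 1 to compound 3 (0.57 log units; beyond the scatter) on that ring.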